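This account rests on a few compounds, and the source may have more. Where it says the series, first, only, none or still open, it means among the compounds named here.

Compound 1, `Nc1ccccc1NC(=O)c1ccc(COc2ccccc2)cc1`: 6760 nM
Compound 2, `Cc1ccc(OCc2ccc(C(=O)Nc3ccccc3N)cc2)cc1`: 5430 nM

Both numbers come from a functional assay on A549 cells (Homo sapiens) for antiproliferative activity, read by CCK-8 assay, with a stated time of 72 h (on this read-out lower numbers stand for stronger inhibition and higher numbers for weaker inhibition), in which compound 1 gives 6760 nM and compound 2 gives 5430 nM. On these two numbers compound 2 stands within the usual scatter of compound 1, the step between them being a 1.2-fold lower number from compound 1 to compound 2 (0.10 log units; within the scatter).

Compound 3, `Nc1ccccc1NC(=O)c1ccc(COc2ccc(F)cc2)cc1`, has not yet been measured in this assay. It differs from compound 2 by fluoro in place of methyl on an aromatic carbon. Within the data shown here, the only measured step that bears on this change is a 1.2-fold lower number from compound 1 to compound 2 (0.10 log units; within the scatter), which altered the same aromatic carbon and stayed within the scatter. Swapping one small group for another at a place where adding a group did little gives no reason to expect a step beyond the scatter in either direction.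

Compound 3 is therefore expected to give about 5500 nM, with a likely range from 2500 nM to 12000 nM. The estimated step of a 1.0-fold higher number from compound 2 to compound 3 (0.01 log units; within the scatter) is expected to stay within the scatter.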

Compound 3, half-maximal inhibitory concentration: 5370 nM
Beside the measured number, compound 3's estimate is 1.0-fold (0.01 log units) above it, within the range that was stated.
By their numbers in this assay, from the lowest: compounds 3, 2 and 1 (each within the scatter of the next).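

Fluoro at this ring carbon, para to a large group, leaves the number within the scatter in this assay, both against methyl (a 1.0-fold lower number from compound 2 to compound 3 (0.00 log units; within the scatter)) and against hydrogen (a 1.3-fold lower number from compound 1 to compound 3 (0.10 log units; within the scatter)). Hydrogen, methyl and fluoro have now all been seen at this one carbon, so the flat result no longer rests on a single substituent, and no step among compounds 1, 2 and 3 lies beyond the scatter. Nothing measured here explains why these three compounds read alike.

All three groups are small, each entering group being a single heavy atom, so the compounds shown cannot tell whether a larger or charged group at this carbon, such as an amine, a carboxylic acid or a longer alkyl chain, would also stay within the scatter. As far as these compounds go, whether the other carbons of this ring respond in the same way also remains open.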